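This account rests on a few compounds, and the source may have more. Where it says the series, first, only, none or still open, it means among the compounds named here.

Compound 1 `O=C(CN1C(=O)S/C(=C/c2ccco2)C1=O)Nc1ccc(Cl)c(Cl)c1`: 72200 nM
Compound 2 `O=C(CN1C(=O)S/C(=C/c2ccco2)C1=O)Nc1ccc(Cl)cc1C(F)(F)F`: > 100000 nM
Compound 3 `O=C(CN1C(=O)S/C(=C/c2ccco2)C1=O)Nc1nc2ccccc2s1`: 15300 nM

In a functional assay on KCL-22 cells (Homo sapiens) for cytotoxicity, read by propidium iodide staining, with a stated time of 48 h (on this read-out lower numbers stand for higher toxicity in this test and higher numbers for lower toxicity in this test), compound 1 gives 72200 nM and stands highest of the two true numbers, while compound 3 at 15300 nM lies lower by more than the scatter. Compound 2 gives only a limit (> 100000 nM). Compound 4 `Cc1cc(NC(=O)CN2C(=O)S/C(=C/c3ccco3)C2=O)no1` has not yet been measured. It carries 5-methyl-1,2-oxazol-3-yl in place of 3,4-dichlorophenyl on an amide-type nitrogen, and the counted change is 5-methyl-1,2-oxazol-3-yl in place of 3,4-dichlorophenyl on an amide-type nitrogen on the shared core. The expected change is a 1.4-fold lower number from compound 1 to compound 4 (0.16 log units; within the scatter) in this assay and no larger than the scatter. The slight lean to a lower number rests on compound 3 at 15300 nM alone. Compound 4 is expected at 50000 nM within an estimated range of 15000 nM to 100000 nM and may return only a limit.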

Compound 4, half-maximal cytotoxic concentration: > 100000 nM
Compound 4 gave a limit, no number; the forecaster's own chance of this, stated with the estimate: 35%; at least 2.0-fold (0.30 log units) between middle value and limit.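

In this assay compound 4 returns only a limit (> 100000 nM), not a number. Putting 5-methyl-1,2-oxazol-3-yl in place of 3,4-dichlorophenyl on an amide-type nitrogen gives an at least 1.3-fold higher number from compound 1 to compound 4 (0.14 log units; that floor lies within the scatter), so this five-membered aromatic ring with 2 hetero atoms brings no lower number at this position. That limit recurs among the compounds shown: the limit of > 100000 nM in this assay, at which 2 of the 4 values shown sit.

How far compound 4 lies past its limit stays unread, so only a floor exists for this step. Going by these compounds, whether an amine, a carboxylic acid or a longer chain on this nitrogen would give a lower number remains open.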